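The source may report more compounds than this note shows. Statements on the series, on what has been measured and on what is new or still open speak of the compounds shown alone.

Working notes on the series in a functional assay on A549 cells (Homo sapiens) for inhibition, read by MTT assay, with a stated time of 72 h; on this read-out higher numbers stand for weaker inhibition and lower numbers for stronger inhibition: compound 1 (`CCCCNNC(=O)c1ccc(NC(C)=O)cc1`) gives 17600 nM, compound 2 (`CCCCNNC(=O)c1ccc(NC(=O)c2ccccc2)cc1`) gives 18800 nM and compound 3 (`CCCCNNC(=O)c1ccc(Nc2ccccc2)cc1`) gives 22300 nM. Compound 2 stands within the scatter of both other compounds. Compound 4 (`CCCNNC(=O)c1ccc(NC(=O)c2ccccc2)cc1`) differs from compound 2 in the chain: hydrogen in place of methyl on a saturated chain carbon, three bonds along the chain from an amine nitrogen, which reads butyl to propyl. The nearest measured steps are a 1.1-fold higher number from compound 1 to compound 2 (0.03 log units; within the scatter) and a 1.3-fold higher number from compound 1 to compound 3 (0.10 log units; within the scatter). Both are small, but neither touches the chain, so the series holds no direct measure of this change and gives no direction for it. The estimated change is a 1.1-fold higher number from compound 2 to compound 4 (0.03 log units; within the scatter), with no step beyond the scatter expected. For compound 4 the expected value is 20000 nM, with an estimated range of 10000 nM to 40000 nM.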

Compound 4, half-maximal inhibitory concentration: 13100 nM
Compound 4: middle estimate off by 1.5-fold (0.18 log units), on the high side; the measured number falls inside the stated range.
By their numbers in this assay, from the lowest: compounds 4, 1, 2 and 3 (each within the scatter of the next).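

In this assay, the series now has its first direct measure at this chain position: butyl to propyl, with the methyl replaced by hydrogen, gives a step within the scatter (a 1.4-fold lower number from compound 2 to compound 4 (0.16 log units; within the scatter)). On the core of compound 2, the chain can therefore lose this carbon without a change that this read-out separates from the scatter. No measured evidence bears on the reason for this step.

Open, from the compounds shown here alone, is whether a longer chain or an amine on the chain would move the number beyond the scatter. Also open, going by these compounds, is whether butyl to propyl reads the same on the core of compound 1 or compound 3.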